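A few compounds are considered here, and "the series" means these few. Any claim that something is new, unique, unknown or untested is made for them only; others in the source may bear on it.

Measured so far in a functional assay on U2OS cells for antagonist activity at proto-oncogene Wnt-3 (Homo sapiens), read by a luciferase reporter, with a stated time of 18 h; a lower number here means that less compound is needed, a higher number that more compound is needed for the effect:

compound 1, `O=C(Cn1ccnc1)N1CCC(NS(=O)(=O)c2cc(S(=O)(=O)c3ccccc3)ccc2C(F)(F)F)CC1`: 230 nM
compound 2, `CN(C)CC(=O)N1CCC[C@H]1C(=O)N1CCC(NS(=O)(=O)c2cc(S(=O)(=O)c3ccccc3)ccc2C(F)(F)F)CC1`: 310 nM
compound 3, `CC(C)(C)NC(=O)N1CCC[C@H]1C(=O)N1CCC(NS(=O)(=O)c2cc(S(=O)(=O)c3ccccc3)ccc2C(F)(F)F)CC1`: 30 nM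

Compound 1 gives the second highest of these three numbers. Compound 2 is its nearest neighbour, with a 1.3-fold higher number from compound 1 to compound 2 (0.13 log units; within the scatter). Compound 3 is the furthest, with a 7.7-fold lower number from compound 1 to compound 3 (0.88 log units; beyond the scatter). Between those two lies a 10-fold lower number from compound 2 to compound 3 (1.01 log units; beyond the scatter).

Compound 4, `CC(C)(C)CCN1CCC[C@H]1C(=O)N1CCC(NS(=O)(=O)c2cc(S(=O)(=O)c3ccccc3)ccc2C(F)(F)F)CC1`, has not yet been measured. Compared with compound 1 the change is 1-(3,3-dimethylbutyl)pyrrolidin-2-yl in place of (1H-imidazol-1-yl)methyl on a carbonyl carbon. Both measured steps from compound 1 bear on it, since each also replaces the same group on the same carbonyl carbon with a pyrrolidin-2-yl carrying something on its ring nitrogen. The step to compound 3 carried a (tert-butyl)carbamoyl group and gave a modest drop; the step to compound 2 carried a ((dimethylamino)methyl)carbonyl group and stayed within the scatter. Compound 4 carries a 3,3-dimethylbutyl group there instead, so a step somewhere between those two outcomes is expected: a 2.3-fold lower number from compound 1 to compound 4 (0.36 log units; beyond the scatter). Compound 4 is estimated to give 100 nM in this assay, within a range from 25 nM to 400 nM.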

Compound 4, half-maximal effective concentration: 450 nM
The estimate for compound 4 lay 4.5-fold (0.65 log units) below the measured number, and the stated range ends below it.
By their numbers in this assay, from the lowest: compound 3; then compounds 1, 2 and 4 (each within the scatter of the next).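

With a 3,3-dimethylbutyl group on the amine nitrogen in the ring, the number stays within the scatter of both compound 1 (a 2.0-fold higher number from compound 1 to compound 4 (0.29 log units; within the scatter)) and compound 2 (a 1.5-fold higher number from compound 2 to compound 4 (0.16 log units; within the scatter)), so placing a pyrrolidin-2-yl on this carbonyl carbon does not by itself lower the number. Only the (tert-butyl)carbamoyl group of compound 3 stands apart (a 15-fold higher number from compound 3 to compound 4 (1.18 log units; beyond the scatter)), so among these compounds the low number goes with that group and not with the ring. Nothing available here explains this difference.

As far as these compounds go, it remains open which part of the (tert-butyl)carbamoyl group matters: a methylcarbamoyl group would vary the tert-butyl end, and a 2,2-dimethylpropanoyl group would remove the amide hydrogen. Also open, from the compounds shown here alone, is how a pyrrolidin-2-yl with a free amine would compare.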